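This account rests on a few compounds, and the source may have more. Where it says the series, first, only, none or still open, it means among the compounds named here.

Series notes. Compound 3 `Cc1ccc(N2C(=O)COc3ccc(-c4cnc(Cl)c(NS(=O)(=O)c5ccc(F)cc5)c4)cc32)cc1` carries a 4-methylphenyl on an amide-type nitrogen in a ring; in a functional assay on HeLa cells (Homo sapiens) for antiproliferative activity, read by MTT assay, with a stated time of 72 h (on this read-out lower numbers stand for stronger inhibition and higher numbers for weaker inhibition), compound 3 gives 32300 nM. Compound 2 `CC(C)N1C(=O)COc2ccc(-c3cnc(Cl)c(NS(=O)(=O)c4ccc(F)cc4)c3)cc21`, with isopropyl at the same nitrogen, gives 5380 nM in this assay. Compound 1 `O=C1COc2ccc(-c3cnc(Cl)c(NS(=O)(=O)c4ccc(F)cc4)c3)cc2N1c1ccc(Cl)cc1` sits at the limit of > 40000 nM in this assay, at which 1 of the 3 values shown sits, so its value > 40000 nM in this assay is a limit and not a number. Of the two numbers shown, compound 3 stands highest, with compound 2 nearest: a 6.0-fold higher number from compound 2 to compound 3 (0.78 log units; beyond the scatter). The step from compound 1 to compound 2 points the same way: an at least 7.4-fold lower number from compound 1 to compound 2 (0.87 log units; beyond the scatter).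

Compound 4 `O=C1COc2ccc(-c3cnc(Cl)c(NS(=O)(=O)c4ccc(F)cc4)c3)cc2N1C1CC1` is not yet measured; it differs from compound 3 by cyclopropyl in place of 4-methylphenyl on an amide-type nitrogen in a ring. Both measured steps show that 4-chlorophenyl or 4-methylphenyl on that nitrogen gives a higher number than isopropyl, so exchanging the 4-methylphenyl for cyclopropyl is expected to lower the number in this assay by roughly the size of a 6.0-fold higher number from compound 2 to compound 3 (0.78 log units; beyond the scatter) in reverse. Compound 4 is therefore estimated at 6000 nM, between 2500 nM and 15000 nM. This corresponds to an expected step of a 5.4-fold lower number from compound 3 to compound 4 (0.73 log units; beyond the scatter).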

Compound 4, half-maximal inhibitory concentration: 7180 nM
Compound 4: middle estimate off by 1.2-fold (0.08 log units), on the low side; measured number inside the range.
By their numbers in this assay, from the lowest: compounds 2 and 4 (each within the scatter of the next); then compound 3. At a limit, above all of these: compound 1.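

In this assay, a ring on the amide-type nitrogen does not by itself go with the higher number: cyclopropyl in place of 4-methylphenyl gives a 4.5-fold lower number from compound 3 to compound 4 (0.65 log units; beyond the scatter). Cyclopropyl and isopropyl cannot be told apart at this position, with a 1.3-fold higher number from compound 2 to compound 4 (0.13 log units; within the scatter), so two different small carbon groups now share the lower level, against the 4-methylphenyl of compound 3. The step of an at least 5.5-fold lower number from compound 1 to compound 4 (0.74 log units; beyond the scatter) is only a floor, the value of compound 1 being a limit and not a number: the limit of > 40000 nM in this assay, at which 1 of the 4 values shown sits.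

All the groups shown on this nitrogen are built of carbon alone, so what a chain ending in an amine or a carboxylic acid would do there stays open. Also open, on these data alone, is whether a longer chain such as n-butyl would stay at the level of compound 2 and compound 4.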